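Notes on the step from compound 2 to compound 3

The source may report more compounds than this note shows. Statements on the series, on what has been measured and on what is new or still open speak of the compounds shown alone.

Measured in a functional assay on MCF7 cells (Homo sapiens) for inhibition, read by sulforhodamine B assay; on this read-out lower numbers stand for stronger inhibition and higher numbers for weaker inhibition:
- compound 1 `O=C1C=C(NCc2ccccc2)C(=O)c2c1nc1n2[C@H]2OC[C@@H](O)[C@H]2OC1`: > 8000 nM (a limit)
- compound 2 `O=C1C=C(Nc2ccc(I)cc2)C(=O)c2c1nc1n2[C@H]2OC[C@@H](O)[C@H]2OC1`: 2230 nM

Among the measured compounds shown here, compound 2 holds the only actual number so far, at 2230 nM. Compound 1 stands at a limit, > 8000 nM. For the measured compounds named here, the single measured step, an at least 3.5-fold lower number from compound 1 to compound 2 (0.55 log units; beyond the scatter), lies beyond the scatter, and its size is open-ended since it rests on (the limit of > 8000 nM in this assay, at which 1 of the 2 values shown sits).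

Compound 3 `COc1cccc(NC2=CC(=O)c3nc4n(c3C2=O)[C@H]2OC[C@@H](O)[C@H]2OC4)c1` keeps the shared core and changes one place: 3-methoxyphenyl in place of 4-iodophenyl on an amine nitrogen. Going by the values given here, that step swapped benzyl for 4-iodophenyl, so it bears only loosely on this exchange, and no measured pair compares two substituted phenyl groups. No shift beyond the scatter in this assay is therefore expected, and no direction can be favoured. The expected change is a 1.1-fold higher number from compound 2 to compound 3 (0.05 log units; within the scatter). Compound 3 is estimated at 2500 nM, with an expected range of 900 nM to 7000 nM.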

Compound 3, half-maximal inhibitory concentration: > 4000 nM
Compound 3 gave a limit, no number (the forecaster's own chance of this, stated with the estimate: 15%); at least 1.6-fold (0.20 log units) between middle value and limit.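

In this assay, the exchange on an amine nitrogen now compares two substituted phenyl groups directly, and the result is an at least 1.7-fold higher number from compound 2 to compound 3 (0.25 log units; that floor lies within the scatter). Compound 3 stands at a limit, > 4000 nM, so this step has only a floor, which does not separate 3-methoxyphenyl from 4-iodophenyl, while a larger loss remains possible. Among the compounds shown here, compound 2 therefore still holds the only actual number, and the step from compound 1 to compound 3 cannot be read, as both ends are limits.

Open, going by these compounds, is whether 4-methoxyphenyl or 3-iodophenyl on the same nitrogen would read like compound 2 or like compound 3, which would separate the substituent from its ring position. Also open, on these data alone, is how plain phenyl, or a phenyl carrying a carboxylic acid, would read in this assay.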